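This account rests on a few compounds, and the source may have more. Where it says the series, first, only, none or still open, it means among the compounds named here.

In an assay on cells for agonist activity at ecdysone receptor (Bombyx mori), read by a luciferase reporter, with a stated time of 24 h (a lower number here means that less compound is needed, a higher number that more compound is needed for the effect), compound 3 `CC(C)(C)N(NC(=O)c1ccccc1Br)C(=O)c1ccccc1Cl` gives 316 nM, the second highest of the three numbers measured. Compound 1 `COc1ccccc1C(=O)N(NC(=O)c1ccccc1)C(C)(C)C` gives 525 nM, a value within the scatter of compound 3, while compound 2 `Cc1cc(C)cc(C(=O)N(NC(=O)c2ccccc2)C(C)(C)C)c1` gives 69.2 nM, a clearly lower number. Among the compounds with values here, the only step between two measured compounds differing in one place is a 7.6-fold lower number from compound 1 to compound 2 (0.88 log units; beyond the scatter), and that exchange sits on a different carbonyl carbon from the one altered here. Compound 4 `CC(C)(C)N(NC(=O)c1ccc(F)cc1)C(=O)c1ccccc1Cl` differs from compound 3 by 4-fluorophenyl in place of 2-bromophenyl on a carbonyl carbon. Within the data shown here, no measured step touches this carbonyl carbon, so the set gives no direct guide to size or direction; the one step that exists shows only that an aryl exchange elsewhere can shift the number well beyond the scatter. Compound 4 is therefore expected to give about 260 nM, with a range from 80 nM to 850 nM. The step this estimate implies, a 1.2-fold lower number from compound 3 to compound 4 (0.08 log units; within the scatter), is expected to lie within the scatter.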

Compound 4, half-maximal effective concentration: 389 nM
Estimate against measurement, compound 4: 1.5-fold (0.17 log units) below; low and high end bracket the measured number.
By their numbers in this assay, from the lowest: compound 2; then compounds 3, 4 and 1 (each within the scatter of the next).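

In this assay, the exchange of 2-bromophenyl for 4-fluorophenyl on the carbonyl carbon whose other neighbour is the amide-type nitrogen gives a 1.2-fold higher number from compound 3 to compound 4 (0.09 log units; within the scatter). Within the data shown here, this is the first measured step at this carbonyl carbon, and it shows that, with 2-chlorophenyl on the other carbonyl, this exchange does not move the number beyond the scatter, unlike the step at the other carbonyl carbon, a 7.6-fold lower number from compound 1 to compound 2 (0.88 log units; beyond the scatter). The exchange alters both the halogen and where it sits on the ring, and no measurement here bears on why the number holds.

The compounds leave open whether a cyclohexyl ring or a longer alkyl chain on this carbonyl carbon would keep the number in the same range. They also leave open whether 4-fluorophenyl would behave the same way with 3,5-dimethylphenyl on the other carbonyl.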